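The compounds below may be only part of what the source reports. "The series", "measured", "known", "first", "only" and "open" are said of these compounds alone.

For the measured compounds named here, in an ADME assay on a cell-free system (plasma, Rattus norvegicus, strain Sprague-Dawley) for metabolic stability, read by LC-MS, tested at 1 uM (on this read-out higher numbers stand for a longer-lived compound and lower numbers for a shorter-lived compound), compound 2 `CC(=O)OCC1CN(C(C)=O)CCN1S(=O)(=O)c1ccc(F)cc1` gives 0.483 h, the only plain number so far. Compound 1 `CC(=O)N1CCN(S(=O)(=O)c2ccc(F)cc2)C(CO)C1` gives a reading that is a limit of the assay, >= 4 h, as noted in the limit of >= 4 h in this assay, at which 1 of the 2 values shown sits. Compound 3 `COCC1CN(C(C)=O)CCN1S(=O)(=O)c1ccc(F)cc1` is not yet measured; it differs from compound 2 by methyl in place of acetyl on an oxygen on a saturated carbon, so it carries no acetyl either. Going by the values given here, only one measured step bears on this change, and it runs the other way: an at least 8.2-fold lower number from compound 1 to compound 2 (0.91 log units; beyond the scatter), where hydrogen stood in place of the acetyl. Compound 3 also lacks the acetyl, although a methyl stands on that oxygen instead of hydrogen, so a large rise in half-life is expected, an 8.3-fold higher number from compound 2 to compound 3 (0.92 log units; beyond the scatter). Compound 3 is expected to reach about 4 h, with a range from 1.2 h to 10 h, and may well be reported only as a limit again.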

Compound 3, half-life: >= 4 h
Compound 3 ended at the assay's limit; the forecaster's own chance of this, stated with the estimate: 50%; the middle value sits exactly at the limit.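

Replacing the acetyl on that oxygen with methyl gives an at least 8.2-fold higher number from compound 2 to compound 3 (0.91 log units; beyond the scatter) in this assay. For the compounds shown here, earlier, the only comparison was between acetyl and hydrogen, so the long half-life might have depended on hydrogen being on that oxygen. Compound 3 shows that a methyl there also gives a reading at the limit of the assay, so among these three compounds only compound 2, the one with acetyl, has a short half-life.

The step from compound 1 to compound 3 cannot be read, so any difference between hydrogen and methyl on this oxygen stays hidden because both readings are limits: the limit of >= 4 h in this assay, at which 2 of the 3 values shown sit. The compounds shown also leave open how a longer ether chain such as ethyl, or a larger ester such as benzoyl, would read at this oxygen.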